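A few compounds are considered here, and "the series" means these few. Any claim that something is new, unique, unknown or untested is made for them only; others in the source may bear on it.

Compound 1 `Cc1ccsc1[C@@H]1C[C@H](O)Cc2ccccc2N1` gives 616000 nM in an ADME assay on Vero cells (Chlorocebus sabaeus) for cytotoxicity; a lower number here means that less compound is tolerated, a higher number that more compound is tolerated. Compound 2 `Cc1ccsc1[C@@H]1C[C@H](O)Cc2cc(OC(F)(F)F)ccc2N1` carries trifluoromethoxy in place of hydrogen on an aromatic carbon, and in this assay compound 2 gives 26700 nM, which is a 23-fold lower number from compound 1 to compound 2 (1.36 log units; beyond the scatter). Compound 3 `O[C@@H]1Cc2ccccc2N[C@H](c2ccco2)C1` differs from compound 1 by furan-2-yl in place of 3-methylthiophen-2-yl on a saturated ring carbon. In this assay compound 3 reaches only a limit of the assay, > 1300000 nM. The step is therefore an at least 2.1-fold higher number from compound 1 to compound 3 (0.32 log units; beyond the scatter), resting on (the limit of > 1300000 nM in this assay, at which 1 of the 3 values shown sits). Compound 4 `O[C@@H]1Cc2cc(OC(F)(F)F)ccc2N[C@H](c2ccco2)C1` has not yet been measured in this assay; it differs from compound 3 by trifluoromethoxy in place of hydrogen on an aromatic carbon, the same change as from compound 1 to compound 2. Because that change gave a 23-fold lower number from compound 1 to compound 2 (1.36 log units; beyond the scatter), compound 4 is expected to show a step of an at least 13-fold lower number from compound 3 to compound 4 (1.11 log units; beyond the scatter). Compound 4 is thus estimated to give 100000 nM in this assay, between 30000 nM and 500000 nM.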

Compound 4, half-maximal cytotoxic concentration: 166000 nM
Beside the measured number, compound 4's estimate is 1.7-fold (0.22 log units) below it; low and high end bracket the measured number.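

In this assay, trifluoromethoxy in place of hydrogen on an aromatic carbon again gives a lower number on the core of compound 3, an at least 7.8-fold lower number from compound 3 to compound 4 (0.89 log units; beyond the scatter), the same direction as on the core of compound 1: the same change on two cores in this assay, a 23-fold lower number (1.36 log units; beyond the scatter) from compound 1 to compound 2 and an at least 7.8-fold lower number (0.89 log units; beyond the scatter) from compound 3 to compound 4; the limit leaves it open whether they differ. Furan-2-yl in place of 3-methylthiophen-2-yl likewise gives a higher number with trifluoromethoxy present, a 6.2-fold higher number from compound 2 to compound 4 (0.79 log units; beyond the scatter), the same direction as without it: the same change on two cores in this assay, an at least 2.1-fold higher number (0.32 log units; beyond the scatter) from compound 1 to compound 3 and a 6.2-fold higher number (0.79 log units; beyond the scatter) from compound 2 to compound 4; the limit leaves it open whether they differ. The direction of each change thus carries over between the two cores, but whether its size does stays unsettled, since compound 3 stands at a limit of the assay: the limit of > 1300000 nM in this assay, at which 1 of the 4 values shown sits.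

The compounds shown leave open how a chlorine atom, an amine or a carboxylic acid on that aromatic carbon would read in this assay. They also leave open whether a phenyl group on the saturated ring carbon would follow the same direction.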